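Aryl group on the ring nitrogen: compounds 1 to 4

The source may report more compounds than this note shows. Statements on the series, on what has been measured and on what is new or still open speak of the compounds shown alone.

Measured so far in a functional assay on A549 cells (Homo sapiens) for cytotoxicity, read by MTT assay, with a stated time of 24 h; on this read-out lower numbers stand for stronger inhibition and higher numbers for weaker inhibition:
compound 1 `COc1ccc(/C=C\C(=O)O)c(OCc2cn(-c3ccccc3I)nn2)c1CC=C(C)C` gives 2200 nM
compound 2 `COc1ccc(-n2cc(COc3c(/C=C\C(=O)O)ccc(OC)c3CC=C(C)C)nn2)cc1` gives 10200 nM
compound 3 `COc1ccccc1-n1cc(COc2c(/C=C\C(=O)O)ccc(OC)c2CC=C(C)C)nn1` gives 43000 nM

Compound 2 stands second highest of the three numbers. Its nearest neighbour is compound 3, reached by a 4.2-fold higher number from compound 2 to compound 3 (0.62 log units; beyond the scatter); the furthest is compound 1, from which compound 2 is reached by a 4.6-fold higher number from compound 1 to compound 2 (0.67 log units; beyond the scatter). Both steps change only the aryl group on the ring nitrogen.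

Compound 4 `COc1ccc(/C=C\C(=O)O)c(OCc2cn(-c3ccccc3C#N)nn2)c1CC=C(C)C` is the next variation at the same place: 2-cyanophenyl in place of 4-methoxyphenyl on an aromatic nitrogen. For the measured compounds named here, no measured compound carries a nitrile, so the change has no direct precedent. What bears on it is that exchanging the aryl group on this nitrogen has twice given a modest step, and that the two aryl groups seen so far with a substituent pattern like that of 2-cyanophenyl gave the two ends of the range: 2-iodophenyl the lowest number, 2-methoxyphenyl the highest, the pair separated by a 20-fold higher number from compound 1 to compound 3 (1.29 log units; beyond the scatter). A modest step from compound 2 in this assay is therefore expected, its direction uncertain; a slightly lower number is taken as the central guess, the expected step being a 1.7-fold lower number from compound 2 to compound 4 (0.23 log units; within the scatter).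

Compound 4 is estimated at 6000 nM, within a range of 1500 nM to 25000 nM.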

Compound 4, half-maximal inhibitory concentration: 38600 nM
Estimate against measurement, compound 4: 6.4-fold (0.81 log units) below; measured number outside the range, above it.
By their numbers in this assay, from the lowest: compound 1; then compound 2; then compounds 4 and 3 (each within the scatter of the next).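

In this assay, the nitrile gives no separation from the methoxy group on this aromatic carbon, with a 1.1-fold lower number from compound 3 to compound 4 (0.05 log units; within the scatter), so 2-cyanophenyl and 2-methoxyphenyl sit at one level, and a shared substitution pattern alone does not place an aryl group at the low end of the range. The low number of compound 1 now stands apart from two different replacements of iodo: besides the earlier step to compound 3, there is an 18-fold higher number from compound 1 to compound 4 (1.24 log units; beyond the scatter), and 4-methoxyphenyl also keeps a lower number than 2-cyanophenyl, with a 3.8-fold higher number from compound 2 to compound 4 (0.58 log units; beyond the scatter). No measured information here bears on why these aryl groups differ in this way.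

Going by these compounds, it remains open whether the low number of compound 1 is particular to iodo or would also appear with bromo or chloro on the same aromatic carbon, and where an unsubstituted phenyl would fall against these four compounds. Also open, on these data alone, is whether 4-cyanophenyl would match 4-methoxyphenyl, which would show whether the nitrile gives the same number wherever it sits on the aryl ring.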